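The source may report more compounds than this note shows. Statements on the series, on what has been measured and on what is new or still open speak of the compounds shown alone.

Measured so far:
compound 1, `O=C(OC1C=CC(n2ccc(=O)[nH]c2=O)C1)c1ccccc1`: > 250000 nM
compound 2, `Cc1cc(=O)n(C(=O)c2ccccc2)c(=O)n1C1C=CC(OC(=O)c2ccccc2)C1`: 191000 nM

In an ADME assay on CCRF-CEM cells (Homo sapiens) for cytotoxicity, with a stated time of 3 days (a lower number here means that less compound is tolerated, a higher number that more compound is tolerated), compound 1 gives > 250000 nM, which is a limit of the assay rather than a number. Compound 1 therefore sits at the limit of > 250000 nM in this assay, at which 1 of the 2 values shown sits. In this assay compound 2 gives 191000 nM. Compound 3, `Cc1cc(C)cc(Cn2c(=O)ccn(C3C=CC(OC(=O)c4ccccc4)C3)c2=O)c1`, has not yet been measured; it differs from compound 1 by 3,5-dimethylbenzyl in place of hydrogen on an aromatic nitrogen. Among the compounds with values here, no measured pair with this kind of change is available for comparison. The step expected here is an at least 1.6-fold lower number from compound 1 to compound 3 (0.22 log units; that floor lies within the scatter), a slight move toward less compound tolerated, close to the scatter. Compound 3 is thus expected to give about 150000 nM, between 40000 nM and 300000 nM.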

Compound 3, half-maximal cytotoxic concentration: 40000 nM
The estimate for compound 3 lay 3.8-fold (0.57 log units) above the measured number, and the stated range covers the measured number.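

In this assay, 3,5-dimethylbenzyl in place of hydrogen on the aromatic nitrogen gives an at least 6.2-fold lower number from compound 1 to compound 3 (0.79 log units; beyond the scatter). This single pair shows that the position is not indifferent to substitution, since this large carbon-only group moves the number toward less compound tolerated. The true size of the step remains unknown, as the value for compound 1 is a limit and the step is only a floor: the limit of > 250000 nM in this assay, at which 1 of the 3 values shown sits.

One pair cannot show whether the benzyl ring or its two methyl groups matter. A plain methyl, an unsubstituted benzyl or a chain ending in an amine on this nitrogen could each behave differently.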